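A few compounds are considered here, and "the series" means these few. Any claim that something is new, unique, unknown or untested is made for them only; others in the source may bear on it.

Compound 1 `Cc1ccc(Cn2cc(COc3ccc4c(=O)ccoc4c3)nn2)cc1` is the reference point. Among the measured compounds shown here, in a functional assay on A549 cells (Homo sapiens) for cytotoxicity, read by MTT assay, with a stated time of 48 h (a lower number here means a stronger inhibitor, a higher number a weaker inhibitor), compound 1 gives 50700 nM, the only outright number among the three values measured so far. Compound 2 `O=c1ccoc2cc(OCc3cn(Cc4ccc([N+](=O)[O-])cc4)nn3)ccc12` has nitro in place of methyl on an aromatic carbon, and in this assay compound 2 reaches only the assay limit, > 100000 nM. Compound 3 `O=c1ccoc2cc(OCc3cn(Cc4ccccc4Br)nn3)ccc12` carries 2-bromophenyl in place of 4-methylphenyl on a saturated chain carbon bound to an aromatic nitrogen, and in this assay compound 3 likewise stops at the assay limit, > 100000 nM. The step of an at least 1.9-fold higher number from compound 1 to compound 2 (0.29 log units; that floor lies within the scatter) and the step of an at least 1.9-fold higher number from compound 1 to compound 3 (0.29 log units; that floor lies within the scatter) each carry a floor that lies within the scatter, so neither shows a clear change; the step that the two limits leave unreadable from compound 2 to compound 3 cannot be read at all, because the limit of > 100000 nM in this assay, at which 2 of the 3 values shown sit, holds both of its values.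

Compound 4 `O=c1ccoc2cc(OCc3cn(Cc4ccccc4Cl)nn3)ccc12` has not yet been measured; it differs from compound 1 by 2-chlorophenyl in place of 4-methylphenyl on a saturated chain carbon bound to an aromatic nitrogen. The closest guide is compound 3, which places a 2-bromophenyl group on the same saturated chain carbon bound to an aromatic nitrogen where compound 4 places 2-chlorophenyl. Compound 4 is therefore expected to reach the same limit, which means an expected step of a 2.6-fold higher number from compound 1 to compound 4 (0.41 log units; beyond the scatter). For compound 4 the estimate in this assay is 130000 nM, within a range from 50000 nM to 350000 nM.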

Compound 4, half-maximal inhibitory concentration: > 100000 nM
Compound 4 gave a limit, no number; the forecaster's own chance of this, stated with the estimate: 65%; the middle value does not contradict the limit.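

Compound 4 stops at a limit of the assay, not a number: in this assay compound 4 gives > 100000 nM. Placing 2-chlorophenyl in place of 4-methylphenyl on this saturated chain carbon gives an at least 1.9-fold higher number from compound 1 to compound 4 (0.29 log units; that floor lies within the scatter), so a third replacement at this position shows no clear change, and compound 1 still holds the only outright number. The steps among compound 2, compound 3 and compound 4, including chloro in place of bromo, cannot be read, because all three values stop at the same limit: the limit of > 100000 nM in this assay, at which 3 of the 4 values shown sit.

Going by these compounds, how far the true values of compound 2, compound 3 and compound 4 lie from compound 1 stays open. Also open, on these data alone, is whether an amine or a carboxylic acid on the phenyl ring, or a longer chain in place of the benzyl group, would give a readable number.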